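Halogenated phenyl groups on a triazole: compound 2 to compound 3

The source may report more compounds than this note shows. Statements on the series, on what has been measured and on what is new or still open speak of the compounds shown alone.

Measured so far:
compound 1 `CC1(C)[C@H]2CC[C@]1(C)N(Cc1cn(-c3cccc(F)c3)nn1)C(=O)C2` — 530 nM
compound 2 `CC1(C)[C@H]2CC[C@]1(C)N(Cc1cn(-c3ccccc3Cl)nn1)C(=O)C2` — 220 nM

Compound 2 gives the lowest number of the two in a functional assay on SGC-7901 cells (Homo sapiens) for inhibition, read by MTT assay, with a stated time of 24 h; a higher number here means a weaker inhibitor, a lower number a stronger inhibitor; compound 1 sits at a higher number, a 2.4-fold lower number from compound 1 to compound 2 (0.38 log units; beyond the scatter). Compound 3 `CC1(C)[C@H]2CC[C@]1(C)N(Cc1cn(-c3cccc(Br)c3)nn1)C(=O)C2` has not been measured. It differs from compound 2 in one place: 3-bromophenyl in place of 2-chlorophenyl on an aromatic nitrogen.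

Among the compounds with values here, only one measured step bears on this change, a 2.4-fold lower number from compound 1 to compound 2 (0.38 log units; beyond the scatter), which swapped a 3-fluorophenyl for a 2-chlorophenyl and lowered the number modestly. Compound 3 returns to a 3-halophenyl, now a 3-bromophenyl, so the expected direction is partly back toward compound 1, though bromine has not been seen in this series. A modest rise in the number is therefore expected, a 1.8-fold higher number from compound 2 to compound 3 (0.26 log units; within the scatter), near the edge of the scatter. Compound 3 is estimated at 400 nM, with a range of 180 nM to 900 nM.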

Compound 3, half-maximal inhibitory concentration: 120 nM
Estimate against measurement, compound 3: 3.3-fold (0.52 log units) above; measured number below the stated range.
By their numbers in this assay, from the lowest: compounds 3 and 2 (each within the scatter of the next); then compound 1.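

Changing only fluoro to bromo on an aromatic carbon gives a 4.4-fold lower number from compound 1 to compound 3 (0.65 log units; beyond the scatter) in this assay and shows that the identity of the halogen on this phenyl ring can matter. The change from 2-chlorophenyl to 3-bromophenyl gives a 1.8-fold lower number from compound 2 to compound 3 (0.26 log units; within the scatter) and leaves compound 2 and compound 3 indistinguishable, even though these two groups carry different halogens at different places on the ring. Nothing measured here offers an explanation for either result.

These compounds cannot separate the contribution of the halogen from that of its place on the ring, since the chloro and bromo groups differ in both. From the compounds shown here alone, it also remains open how a plain phenyl, a methoxy group or a nitrile on this ring would compare with the bromo group of compound 3.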